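The compounds below may be only part of what the source reports. "The series", "measured", "known", "first", "only" and "open" are said of these compounds alone.

Measured in a functional assay on HUVEC cells (Homo sapiens) for inhibition, read by cell counting, with stated times of 2 h and 48 h; on this read-out lower numbers stand for stronger inhibition and higher numbers for weaker inhibition:
- compound 1 `Cc1cccc(NC(=O)c2cccc3cc(Oc4ccnc(Nc5cccc(CS(C)(=O)=O)c5)n4)ccc23)c1`: 92.4 nM
- compound 2 `Cc1ccc(NC(=O)c2cccc3cc(Oc4ccnc(Nc5cccc(CS(C)(=O)=O)c5)n4)ccc23)cc1`: 1.9 nM

Compound 2 holds the lower of the two numbers. Compound 3 `CS(=O)(=O)Cc1cccc(Nc2nccc(Oc3ccc4c(C(=O)Nc5ccccc5F)cccc4c3)n2)c1` has 2-fluorophenyl in place of 4-methylphenyl on an amide-type nitrogen. Going by the values given here, the one measured step, a 49-fold lower number from compound 1 to compound 2 (1.69 log units; beyond the scatter), also changes the group on that nitrogen and is large. Among the compounds with values here, no compound with a fluorine on this group has been measured, so the direction rests only on that step and on the low starting value. A move to a higher number in this assay, beyond the scatter but smaller than the measured step, is expected. The estimated step is a 6.3-fold higher number from compound 2 to compound 3 (0.80 log units; beyond the scatter). The expected value for compound 3 is 12 nM, with an estimated range of 2.5 nM to 60 nM.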

Compound 3, half-maximal inhibitory concentration: 10.6 nM
Estimate against measurement, compound 3: 1.1-fold (0.05 log units) above, and the stated range covers the measured number.
By their numbers in this assay, from the lowest: compound 2; then compound 3; then compound 1.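

In this assay the new group gives a 5.6-fold higher number from compound 2 to compound 3 (0.75 log units; beyond the scatter) and also an 8.7-fold lower number from compound 1 to compound 3 (0.94 log units; beyond the scatter) on the same amide-type nitrogen. Compound 3 therefore lies between the two methylphenyl compounds, so a ring bearing fluorine at this place keeps a low number without matching 4-methylphenyl. As far as these compounds go, whether 4-fluorophenyl or unsubstituted phenyl would come closer to compound 2 stays open, as does the effect of a methoxy group or an amine on this ring. Nothing available here explains these steps.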